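Ring-methyl removal across pyrazolyl and imidazolyl aryl analogues

This account rests on a few compounds, and the source may have more. Where it says the series, first, only, none or still open, it means among the compounds named here.

Compound 1 `CCN(c1ccc(C#N)c(Cl)c1)c1cc(-c2c[nH]nc2C)ccc1C` gives 9030 nM in a functional assay on PC-3 cells (Homo sapiens) for antiproliferative activity, read by CCK-8 assay, with a stated time of 6 days; a lower number here means a stronger inhibitor, a higher number a weaker inhibitor. Compound 3 `CCN(c1ccc(C#N)c(Cl)c1)c1cc(-c2cn[nH]c2)ccc1C` gives 15300 nM in this assay. Compound 2 `CCN(c1ccc(C#N)c(Cl)c1)c1cc(-n2ccnc2)ccc1C` sits at the limit of > 30000 nM in this assay, at which 1 of the 3 values shown sits. In this assay compound 2 is reported only as a limit, > 30000 nM, not a number.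

Compound 1 to compound 3 is hydrogen in place of methyl on an aromatic carbon, and the step is a 1.7-fold higher number from compound 1 to compound 3 (0.23 log units; within the scatter). The cores of compound 1 and compound 2 differ by 1H-imidazol-1-yl in place of 3-methyl-1H-pyrazol-4-yl on an aromatic carbon, with a step of an at least 3.3-fold higher number from compound 1 to compound 2 (0.52 log units; beyond the scatter). The step from compound 2 to compound 3 is an at least 1.9-fold lower number from compound 2 to compound 3 (0.29 log units; that floor lies within the scatter).

Compound 4 `CCN(c1cccc(-n2ccnc2)c1)c1ccc(C#N)c(Cl)c1`, not yet measured, differs from compound 2 by hydrogen in place of methyl on an aromatic carbon. This is the same kind of change as from compound 1 to compound 3, but the place differs: there it is on an aromatic carbon of a five-membered aromatic ring with 2 nitrogen, next to the ring nitrogen; here it is on an aromatic carbon of a six-membered aromatic ring of carbon only, ortho to a large group and para to a 1H-imidazol-1-yl group. The expected step, resting on the within-scatter step a 1.7-fold higher number from compound 1 to compound 3 (0.23 log units; within the scatter), is a step that the limit leaves unreadable from compound 2 to compound 4. Compound 4 is therefore expected to remain weak, around 40000 nM, estimated between 15000 nM and 120000 nM, and likely reported again only as a limit.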

Compound 4, half-maximal inhibitory concentration: > 30000 nM
Compound 4 ended at the assay's limit (the forecaster's own chance of this, stated with the estimate: 70%); the middle value is on the limit's open side.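

Compound 2 and compound 4 are each reported only as a limit, not a number, so no step can be read between them: the limit of > 30000 nM in this assay, at which 2 of the 4 values shown sit.

The compounds shown leave open whether hydrogen in place of methyl on the six-membered aromatic ring of carbon only changes activity in this assay at all.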